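This account rests on a few compounds, and the source may have more. Where it says the series, first, only, none or still open, it means among the compounds named here.

In a functional assay on K562 cells (Homo sapiens) for cytotoxicity, read by MTT assay, with a stated time of 48 h (on this read-out lower numbers stand for stronger inhibition and higher numbers for weaker inhibition), compound 1 (`COC(=O)/C=C/c1ccc2c(c1)C(=O)C(=O)N2Cc1ccccc1`) gives 40 nM and compound 3 (`COC(=O)/C=C/c1ccc2c(c1)C(=O)C(=O)N2Cc1ccc(Cl)c(Cl)c1`) gives 60 nM so these two share the low end of the three measured numbers. Compound 2 (`COC(=O)/C=C/c1ccc2c(c1)C(=O)C(=O)N2`) stands higher at 220 nM on the same scale.

Compound 4 (`COC(=O)/C=C/c1ccc2c(c1)C(=O)C(=O)N2Cc1ccc(C(F)(F)F)cc1`) differs from compound 1 by a single change (trifluoromethyl in place of hydrogen on an aromatic carbon): trifluoromethyl in place of hydrogen on an aromatic carbon, para to a large group. Among the measured compounds shown here, two measured steps bear on it. Hydrogen in place of benzyl gives a 5.5-fold higher number from compound 1 to compound 2 (0.74 log units; beyond the scatter) and lies beyond the scatter, but that step removes the whole group rather than adding to it. The closer comparison, 3,4-dichlorophenyl in place of phenyl, gives a 1.5-fold higher number from compound 1 to compound 3 (0.18 log units; within the scatter) and stays within the scatter. For the measured compounds named here, no compound with trifluoromethyl has been measured yet, so this comparison is only a guide. An estimated step (a 1.5-fold higher number from compound 1 to compound 4 (0.18 log units; within the scatter)) within the scatter is therefore expected in this assay rather than a clear change. The estimated value for compound 4 is 60 nM with 25 nM to 150 nM as the expected range.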

Compound 4, half-maximal inhibitory concentration: 40 nM
Compound 4: the middle estimate sits 1.5-fold (0.18 log units) above what was measured, and the stated range covers the measured number.
By their numbers in this assay, from the lowest: compounds 1, 4 and 3 (each within the scatter of the next); then compound 2.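

In this assay, trifluoromethyl in place of hydrogen on an aromatic carbon, para to a large group, gives no change at the digits printed from compound 1 to compound 4 (within the scatter) and so leaves the read-out where it was. Among the compounds shown here, this shows that the position accepts a group of four heavy atoms with the number staying within the scatter, which adds a second case to the step to 3,4-dichlorophenyl, a 1.5-fold higher number from compound 1 to compound 3 (0.18 log units; within the scatter), while removing the whole benzyl group, a 5.5-fold higher number from compound 1 to compound 2 (0.74 log units; beyond the scatter), remains the only step here that lies beyond the scatter. Nothing measured here explains why the number holds at this position. On these data alone, it remains open whether an amine or a carboxylic acid on this same aromatic carbon would also stay within the scatter. As far as these compounds go, a longer chain in place of the benzyl group on the ring nitrogen is equally open.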